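Hemolysis series: amidinohydrazone to thiosemicarbazone change on two cores

The source may report more compounds than this note shows. Statements on the series, on what has been measured and on what is new or still open speak of the compounds shown alone.

Measured so far:
compound 1 `N=C(N)N/N=C/c1ccc(OCc2ccc3no[n+]([O-])c3c2)cc1`: > 200 uM (a limit)
compound 2 `NC(=S)N/N=C/c1ccc(OCc2ccc3no[n+]([O-])c3c2)cc1`: > 200 uM (a limit)
compound 3 `CC1(C)[N+]([O-])=c2ccc(COc3ccccc3/C=N\NC(=N)N)cc2=[N+]1[O-]`: 114 uM

In an ADME assay on cells (Erythrocyte, Homo sapiens), read by spectrophotometry and hemolysis, with a stated time of 24 h (a higher number here means a weaker inhibitor, a lower number a stronger inhibitor), compound 1 gives only a limit, > 200 uM. Compound 2 also gives only a limit, > 200 uM. For the measured compounds named here, compound 3 gives the single real number in this assay, 114 uM. The change a group of 3 heavy atoms (1 carbon, 1 nitrogen, 1 sulfur; no ring) in place of a group of 3 heavy atoms (1 carbon, 2 nitrogen; no ring), on an amine nitrogen yields a step that the two limits leave unreadable from compound 1 to compound 2; the two values sitting at the limit of > 200 uM in this assay, at which 2 of the 3 values shown sit, leave its size unreadable. The difference between the core of compound 1 and the core of compound 3 is not broken down here.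

Compound 4 `CC1(C)[N+]([O-])=c2ccc(COc3ccccc3/C=N\NC(N)=S)cc2=[N+]1[O-]` carries the same change on the core of compound 3, (a group of 3 heavy atoms (1 carbon, 1 nitrogen, 1 sulfur; no ring) in place of a group of 3 heavy atoms (1 carbon, 2 nitrogen; no ring), on an amine nitrogen), at the same place as before. For compound 4 the step of a 1.1-fold higher number from compound 3 to compound 4 (0.02 log units; within the scatter) is expected to be small, because a step that the two limits leave unreadable from compound 1 to compound 2 has no readable size and offers no ground for a large shift. Compound 4 is therefore estimated at 120 uM, between 50 uM and 250 uM, with a fair chance that this assay returns only a limit.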

Compound 4, concentration for 50% inhibition: > 200 uM
Compound 4: only a limit was reported (the forecaster's own chance of this, stated with the estimate: 35%); at least 1.6-fold (0.22 log units) between middle value and limit.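

In this assay the amidinohydrazone to thiosemicarbazone change on the core of compound 3 gives an at least 1.7-fold higher number from compound 3 to compound 4 (0.24 log units; that floor lies within the scatter). Compound 4 gives > 200 uM, which is a limit and not a number. The same change on the core of compound 1 cannot be read, so the series does not show whether the change carries over from one core to the other with a similar size, and the true size on the core of compound 3 stays unknown, since most values stop at the same limit: the limit of > 200 uM in this assay, at which 3 of the 4 values shown sit.

Still open, going by these compounds, is whether a carbonyl in place of the thiocarbonyl, or a longer chain on the same amine nitrogen, would give a readable number in this assay. The same question holds for a carboxylic acid placed on either core.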